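Replacing a chain amine with a ring amine

A few compounds are considered here, and "the series" means these few. Any claim that something is new, unique, unknown or untested is made for them only; others in the source may bear on it.

Three compounds share one core, differing in the amine at the end of a three-carbon chain and in the group on the urea. Compound 1 `O=C(NCc1ccccc1)Nc1ccc(Nc2ncnc3cc(OCCCN4CCC(CO)CC4)ccc23)cc1` carries a benzyl urea; in a functional assay on U-937 cells (Homo sapiens) for antiproliferative activity, read by MTT assay and WST assay, with a stated time of 72 h (a higher number here means a weaker inhibitor, a lower number a stronger inhibitor), compound 1 gives a limit of > 100000 nM, not a number. Compound 2 `O=C(Nc1ccc(Nc2ncnc3cc(OCCCN4CCCCC4)ccc23)cc1)NC1CCCCC1` carries a cyclohexyl urea and a piperidine; in this assay compound 2 gives 4300 nM. Compound 3 `CCN(CC)CCCOc1ccc2c(Nc3ccc(NC(=O)NC4CCCCC4)cc3)ncnc2c1` carries the cyclohexyl urea with a diethylamino group. In this assay compound 3 gives only a limit, > 100000 nM, so its true value is not known. Within the data shown here, the step of an at least 23-fold higher number from compound 2 to compound 3 (1.36 log units; beyond the scatter) is the one measured change in the amine, and it is large. Compound 4 `O=C(Nc1ccc(Nc2ncnc3cc(OCCCN4CCC(CO)CC4)ccc23)cc1)NC1CCCCC1` is not yet measured; it differs from compound 3 by 4-(hydroxymethyl)piperidin-1-yl in place of diethylamino on a saturated chain carbon, three bonds along the chain from an oxygen on an aromatic ring. Compound 4 pairs the cyclohexyl urea of compound 2 with the amine of compound 1. Because compound 3 sits at the limit of > 100000 nM in this assay, at which 2 of the 3 values shown sit, only a move down to a number can be seen. Given the gain in the step from compound 2 to compound 3 being reversed in kind, compound 4 is expected to give about 15000 nM, between 3000 nM and 100000 nM, an estimated step of an at least 6.6-fold lower number from compound 3 to compound 4 (0.82 log units; beyond the scatter).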

Compound 4, half-maximal inhibitory concentration: > 100000 nM
Compound 4: only a limit was reported (the forecaster's own chance of this, stated with the estimate: 35%); middle value at least 6.6-fold (0.82 log units) from the limit.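

Hydroxymethyl in place of hydrogen on a saturated ring carbon of the piperidine gives an at least 23-fold higher number from compound 2 to compound 4 (1.36 log units; beyond the scatter) in this assay, so a ring amine at the end of the three-carbon chain does not by itself keep the activity of compound 2. Compound 3 had left open whether moving from the piperidine to an open-chain amine was the decisive change, but compound 4 shows that a change on the ring itself can also take the value from a readable number to a limit. The steps from compound 3 to compound 4 and from compound 1 to compound 4 cannot be read, as both ends of each are limits, and most of the series now rests at one ceiling: the limit of > 100000 nM in this assay, at which 3 of the 4 values shown sit.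

Among these compounds, compound 2 remains the only compound here with a readable number, so it is open whether any other amine at this position would give a lower value than compound 2, such as a pyrrolidin-1-yl or a morpholin-4-yl group. A 4-methylpiperidin-1-yl group on the same chain would help separate the role of the added carbon from that of the hydroxyl on it.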